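Swapping the Amide Substituent: Compound 1 to Compound 4

The source may hold more compounds than are shown below. What is called first, only, known or untested is meant among the compounds shown, and "the series" means these compounds.

Compound 1 `COCOc1cc(/C=C/C(=O)OCC(=O)Nc2nccs2)ccc1OCc1ccccc1` was tested in a functional assay on CNE cells (Homo sapiens) for cytotoxicity, read by MTT assay, with a stated time of 72 h; a lower number here means a stronger inhibitor, a higher number a weaker inhibitor. There compound 1 gives only a limit of the assay, > 200000 nM. Two related compounds behave the same way. Compound 2 `COc1ccc(NC(=O)COC(=O)/C=C/c2ccc(O)c(O)c2)cc1` gives a limit of > 200000 nM. Compound 3 `O=C(COC(=O)/C=C/c1ccc(O)c(O)c1)NN1CCOCC1` gives a limit of > 200000 nM. The step from compound 2 to compound 3 is a step that the two limits leave unreadable from compound 2 to compound 3, so its size cannot be read. All three values sit at the limit of > 200000 nM in this assay, at which 3 of the 3 values shown sit. Compound 4 `COCOc1cc(/C=C/C(=O)OCC(=O)Nc2ccc(OC)cc2)ccc1OCc1ccccc1` differs from compound 1 by 4-methoxyphenyl in place of 1,3-thiazol-2-yl on an amide-type nitrogen. Among the compounds with values here, the only measured step near such a change, from compound 2 to compound 3, gives no readable size, so no direction beyond the scatter can be drawn from it. The step from compound 1 to compound 4 is therefore expected to be a step that the limit leaves unreadable from compound 1 to compound 4. Compound 4 is estimated at 300000 nM, within 100000 nM to 1000000 nM, most likely again reported only as a limit.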

Compound 4, half-maximal inhibitory concentration: > 200000 nM
Compound 4 gave a limit, no number; the forecaster's own chance of this, stated with the estimate: 85%; the middle value lies beyond the limit too.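

Compound 1 and compound 4 each give only a limit, so no step between them can be read: the limit of > 200000 nM in this assay, at which 4 of the 4 values shown sit.

The compounds shown leave open whether any substituent on the amide nitrogen would give a measured number rather than a limit in this assay.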